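The source may hold more compounds than are shown below. What is called first, only, known or untested is meant among the compounds shown, and "the series" means these compounds.

Series of 2-(benzylthio)quinazolin-4-amines bearing the 4-(trifluoromethyl)benzylthio group, tested in a functional assay on PC-3 cells (Homo sapiens) for cytotoxicity, read by MTT assay, with a stated time of 72 h; a lower number here means a stronger inhibitor, a higher number a weaker inhibitor. Compound 1 `CCCCCCCCCCCCCCNc1nc(SCc2ccc(C(F)(F)F)cc2)nc2ccccc12` carries a tetradecylamino chain. In this assay compound 1 reports only a limit, > 50000 nM. Within the data shown here, compound 2 `FC(F)(F)c1ccc(CSc2nc(Nc3ccccc3C(F)(F)F)c3ccccc3n2)cc1` gives 34800 nM in this assay, the only numerical value in the set; the other entry sits at the limit of > 50000 nM in this assay, at which 1 of the 2 values shown sits. Compound 3 `O=[N+]([O-])c1cccc(Nc2nc(SCc3ccc(C(F)(F)F)cc3)nc3ccccc23)c1` differs from compound 2 by 3-nitrophenyl in place of 2-(trifluoromethyl)phenyl on a nitrogen on an aromatic ring. Among the measured compounds shown here, no measured pair shows this change, so for compound 3 a step of a 1.2-fold lower number from compound 2 to compound 3 (0.06 log units; within the scatter) is expected, within the scatter, with no clear direction. Compound 3 is estimated at 30000 nM, likely between 10000 nM and 50000 nM.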

Compound 3, half-maximal inhibitory concentration: 13500 nM
Estimate against measurement, compound 3: 2.2-fold (0.35 log units) above; the measured number falls inside the stated range.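

In this assay, among these compounds, the aryl group on this nitrogen changes the read-out: 3-nitrophenyl in place of 2-(trifluoromethyl)phenyl goes with a 2.6-fold lower number from compound 2 to compound 3 (0.41 log units; beyond the scatter), the first step that can be read. The change alters both the group and its printed ring position, so this single pair does not separate the two. Nothing measured here gives a reason for the step. Open, from the compounds shown here alone, is what 3-(trifluoromethyl)phenyl, 2-nitrophenyl or plain phenyl on this nitrogen would give, and whether either effect holds alone.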